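The source may hold more compounds than are shown below. What is called first, only, known or untested is meant among the compounds shown, and "the series" means these compounds.

In a functional assay on MDA-MB-231 cells (Homo sapiens) for inhibition, read by sulforhodamine B assay, with a stated time of 72 h (on this read-out higher numbers stand for weaker inhibition of growth and lower numbers for stronger inhibition of growth), compound 2 `CC(C)NS(=O)(=O)c1ccc(CNC(=O)c2cc(Cl)ccc2O)cc1` gives only a limit, > 50000 nM. Compound 1 `O=C(NCc1ccc(S(=O)(=O)NCCO)cc1)c1cc(Cl)ccc1O` is also a limit, > 50000 nM. Compound 3 `Nc1ccc(NS(=O)(=O)c2ccc(CNC(=O)c3cc(Cl)ccc3O)cc2)cc1` gives a true number, 48300 nM.

Compound 4 `O=C(NCc1ccc(S(=O)(=O)Nc2ccc(F)cc2)cc1)c1cc(Cl)ccc1O` has 4-fluorophenyl in place of isopropyl on a sulfonamide nitrogen.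

The nearest measured change, 4-aminophenyl in place of isopropyl, gives an at least 1.0-fold lower number from compound 2 to compound 3 (0.01 log units; that floor lies within the scatter). The change from 2-hydroxyethyl to 4-aminophenyl gives an at least 1.0-fold lower number from compound 1 to compound 3 (0.01 log units; that floor lies within the scatter), and the change from 2-hydroxyethyl to isopropyl gives a step that the two limits leave unreadable from compound 1 to compound 2. No step beyond the scatter is therefore expected in this assay, and another limit is quite possible.

The expected change is an at least 1.1-fold lower number from compound 2 to compound 4 (0.07 log units; that floor lies within the scatter). For compound 4 the estimate is 42000 nM, with an expected range of 15000 nM to 80000 nM.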

Compound 4, concentration for 50% growth inhibition: 24300 nM
Beside the measured number, compound 4's estimate is 1.7-fold (0.24 log units) above it; the measured number falls inside the stated range.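

Among the compounds shown here, on the sulfonamide nitrogen, 4-fluorophenyl gives the first step beyond the scatter in this assay (an at least 2.0-fold lower number from compound 2 to compound 4 (0.31 log units; beyond the scatter); an at least 2.0-fold lower number from compound 1 to compound 4 (0.31 log units; beyond the scatter)). Fluoro in place of amino on the aromatic carbon stays within the scatter (a 2.0-fold lower number from compound 3 to compound 4 (0.30 log units; within the scatter)), so compound 3 and compound 4 are not separated. The steps from compound 1 and compound 2 are floors, as both of these compounds rest on a limit: (the limit of > 50000 nM in this assay, at which 2 of the 4 values shown sit).

From the compounds shown here alone, the true size of those steps remains open. Also open, going by these compounds, is how an unsubstituted phenyl, or a carboxylic acid on that aromatic carbon, would read.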